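The compounds below may be only part of what the source reports. "The series", "measured", "known", "first", "only" and "open" are said of these compounds alone.

Two compounds share a core in which an unsaturated carboxylic acid chain and a heteroaryl-methyl group sit on a five-membered aromatic ring. Compound 1, `C/C(=C/c1ccc(Cn2ccnc2)n1C)C(=O)O`, carries a methyl on the ring nitrogen and an imidazolylmethyl group; in a functional assay on microsomes from aorta for inhibition of Thromboxane-A synthase (Homo sapiens), in the presence of a further agent that is not named here (a lower number here means a stronger inhibitor, a higher number a weaker inhibitor), compound 1 gives 1000 nM. Compound 2, `C/C(=C/c1ccc(Cc2cccnc2)n1C(C)C)C(=O)O`, carries an isopropyl on that nitrogen and a (pyridin-3-yl)methyl group; in this assay compound 2 gives 2100 nM, the highest of the two numbers, and its distance from compound 1 lies beyond the usual scatter.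

Compound 3, `C/C(=C/c1ccc(Cc2cccnc2)n1C)C(=O)O`, is not yet measured. It differs from compound 2 in one place: methyl in place of isopropyl on an aromatic nitrogen. Among the measured compounds shown here, no measured pair in the set isolates this change, so the expectation rests on the two numbers alone. A small step downward, perhaps no larger than the scatter, is expected, a 1.6-fold lower number from compound 2 to compound 3 (0.21 log units; within the scatter). Compound 3 is therefore estimated at 1300 nM, within a range from 500 nM to 3500 nM.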

Compound 3, half-maximal inhibitory concentration: 50 nM
Beside the measured number, compound 3's estimate is 26-fold (1.41 log units) above it; measured number below the stated range.
By their numbers in this assay, from the lowest: compound 3; then compound 1; then compound 2.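

Compounds 1 and 2 differ in two places, so their close numbers could not show what either change does alone; compound 3 separates the two. With the (pyridin-3-yl)methyl group kept, methyl in place of isopropyl on the aromatic nitrogen gives a 42-fold lower number from compound 2 to compound 3 (1.62 log units; beyond the scatter) in this assay, so this position responds strongly to the choice of alkyl group, while with methyl kept, pyridin-3-yl in place of 1H-imidazol-1-yl gives a 20-fold lower number from compound 1 to compound 3 (1.30 log units; beyond the scatter), so the heteroaryl group matters strongly too. No measurement here explains why either change has so large an effect.

The compounds shown leave open how an ethyl group, or a hydrogen, on that nitrogen would compare with methyl and isopropyl. They also leave open whether isopropyl in place of methyl would have a similar effect on the compound carrying the 1H-imidazol-1-yl group.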